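Thiophen-2-yl in place of furan-2-yl

The source may report more compounds than this note shows. Statements on the series, on what has been measured and on what is new or still open speak of the compounds shown alone.

In a functional assay on PC-3 cells (Homo sapiens) for cytotoxicity (on this read-out lower numbers stand for an effect already at smaller amounts and higher numbers for an effect only at larger amounts of compound), compound 1 `COC1=C(C)C(=O)/C(=C(O)/C=C/c2ccccc2OC)C(=O)C1(C)C` gives 15.6 ug/mL and compound 2 `COC1=C(C)C(=O)/C(=C(O)/C=C/c2ccco2)C(=O)C1(C)C` gives 20.6 ug/mL. These two numbers lie within the usual scatter of repeated measurements, so compound 2 cannot be told apart from compound 1. The next compound, compound 3 `COC1=C(C)C(=O)/C(=C(O)/C=C/c2cccs2)C(=O)C1(C)C`, carries thiophen-2-yl in place of furan-2-yl on a double-bonded chain carbon bound to a double-bonded chain carbon. For the measured compounds named here, only one measured step touches this place. It is a 1.3-fold higher number from compound 1 to compound 2 (0.12 log units; within the scatter), with furan-2-yl in place of 2-methoxyphenyl. That step stayed within the scatter, and no step beyond the scatter is expected in this assay for the exchange of one five-membered aromatic ring for the other. The expected change is a 1.1-fold lower number from compound 2 to compound 3 (0.04 log units; within the scatter). For compound 3 the estimated value is 19 ug/mL, with an expected range from 10 ug/mL to 36 ug/mL.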

Compound 3, concentration for half-maximal effect: 18.2 ug/mL
Estimate against measurement, compound 3: 1.0-fold (0.02 log units) above; measured number inside the range.
By their numbers in this assay, from the lowest: compounds 1, 3 and 2 (each within the scatter of the next).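

Exchanging the ring oxygen of furan-2-yl for the sulfur of thiophen-2-yl, with the ring size and heavy-atom count unchanged, gives a 1.1-fold lower number from compound 2 to compound 3 (0.05 log units; within the scatter) in this assay, so this first exchange of one five-membered aromatic ring for the other cannot be told from the scatter. Thiophen-2-yl in place of 2-methoxyphenyl gives a 1.2-fold higher number from compound 1 to compound 3 (0.07 log units; within the scatter) and also stays within the scatter, so all three aromatic groups shown at this place read alike in this assay. No measurement is available that could explain this likeness.

The compounds shown leave open whether this place responds at all, since each group here is an aromatic ring. A ring carrying a carboxylic acid or an amine could answer that, and a longer chain in place of 2-(thiophen-2-yl)ethenyl could show whether the length of the link matters.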